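Methoxy for fluoro on the aryl ring of compound 1

The source may report more compounds than this note shows. Statements on the series, on what has been measured and on what is new or still open speak of the compounds shown alone.

Compound 1 `Cn1c(-c2cc(-c3ccc(F)cc3)no2)cc2ccccc21` stands only at a limit in a functional assay on Calu-3 cells (Homo sapiens) for cytotoxicity, read by WST assay, with a stated time of 72 h; a higher number here means a weaker inhibitor, a lower number a stronger inhibitor: in this assay compound 1 gives > 100000 nM, a limit of the assay and not a number. Compound 2 `COc1cccc(-c2cc(-c3cc4ccccc4n3C)on2)c1` gives > 100000 nM, also a limit. Both values sit at the limit of > 100000 nM in this assay, at which 2 of the 2 values shown sit. Compound 3 `COc1ccc(-c2cc(-c3cc4ccccc4n3C)on2)cc1` differs from compound 1 by methoxy in place of fluoro on an aromatic carbon. Within the data shown here, no measured step exists for this pair; the step from compound 1 to compound 3 is expected as a number no higher from compound 1 to compound 3 (the limit leaves the size open), none beyond the scatter, because both known values rest at the limit of > 100000 nM in this assay, at which 2 of the 2 values shown sit. Compound 3 is estimated at 100000 nM, between 50000 nM and 300000 nM, most probably reported again as a limit.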

Compound 3, half-maximal inhibitory concentration: > 100000 nM
Compound 3 ended at the assay's limit (the forecaster's own chance of this, stated with the estimate: 85%); the middle value sits exactly at the limit.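

In this assay no step can be read between compound 1 and compound 3: both stand at a limit and not at a number. The compounds shown leave open whether methoxy in place of fluoro changes the true value at all.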